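Nitro for bromo on the anilide ring

The source may hold more compounds than are shown below. What is called first, only, known or untested is meant among the compounds shown, and "the series" means these compounds.

Compound 2 `COc1cc2c(cc1OC)C(CC(=O)Nc1ccc(Br)cc1)CC2` gives 46.3% in a functional assay on the whole organism (strain Wistar) for inhibition, with Rattus norvegicus as the target, read by paw edema, with a stated time of 6 h, at a dose of 100 mg/kg (on this read-out higher numbers stand for more inhibition at the one dose given (going by the name of the read-out) and lower numbers for less inhibition), and stands second highest of the three numbers. Among the compounds with values here, its neighbour compound 3 `COc1cc2c(cc1OC)C(CC(=O)Nc1cccc(C)c1)CC2` gives 38%, a difference within the scatter, and compound 1 `COc1cc2c(cc1OC)C(CC(=O)Nc1ccc(Cl)cc1)CC2` gives 61.1%, the only value set apart from it beyond the scatter. The measured steps are a number 14.8 percentage points lower from compound 1 to compound 2 (beyond the scatter), a number 23.1 percentage points lower from compound 1 to compound 3 (beyond the scatter) and a number 8.3 percentage points lower from compound 2 to compound 3 (within the scatter).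

Compound 4 `COc1cc2c(cc1OC)C(CC(=O)Nc1ccc([N+](=O)[O-])cc1)CC2` differs from compound 2 by nitro in place of bromo on an aromatic carbon. Within the data shown here, of the measured steps only the one from compound 1 to compound 2 touches the same aromatic carbon, where one halogen replaced another and the read-out moved by a modest amount; no measured compound carries a nitro group anywhere, so the direction of this change is not anchored. The expectation is therefore no step beyond the scatter, with the range widened to allow for a modest move either way. This means an expected step of a number 0.7 percentage points higher from compound 2 to compound 4 (within the scatter). Compound 4 is estimated at 47%, within a range from 30% to 64%.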

Compound 4, a percentage reported as inhibition, in the whole organism at one dose (the size of the read-out at that dose, not a potency): 37%
For compound 4 the middle estimate is 10 percentage points above the measured one; the measured number falls inside the stated range.
By their numbers in this assay, from the lowest: compounds 4, 3 and 2 (each within the scatter of the next); then compound 1.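

In this assay nitro in place of bromo gives a number 9.3 percentage points lower from compound 2 to compound 4 (within the scatter), so this aromatic carbon accepts a group with more heavy atoms and with hydrogen-bond acceptors and the read-out stays within the scatter of the bromo compound. Nitro in place of chloro gives a number 24.1 percentage points lower from compound 1 to compound 4 (beyond the scatter) and so compound 1 now stands apart from two different replacements at this position, with bromo and nitro not separable from each other. Nothing measured here accounts for chloro alone standing apart.

The compounds shown leave open whether an amine or a carboxylic acid on this aromatic carbon would fall with compound 1 or with compound 2 and compound 4. Also open, on these data alone, is whether fluoro would hold the level of chloro, and whether the separation of compound 1 persists at other doses.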